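From Nitrile to Amine: Estimating Compound 4

The source may hold more compounds than are shown below. What is called first, only, known or untested is meant among the compounds shown, and "the series" means these compounds.

Compound 3 `N#Cc1ccccc1-c1cnc(C(=O)CCCCCCc2ccccc2)o1` gives 130 nM in an assay (Rattus norvegicus) for inhibition of Fatty-acid amide hydrolase 1 (Homo sapiens); on this read-out lower numbers stand for stronger inhibition and higher numbers for weaker inhibition. This is the second highest of the three numbers: compound 1 `O=C(CCCCCCc1ccccc1)c1ncc(-c2ccccc2F)o1` gives 110 nM, and compound 2 `COc1ccccc1-c1cnc(C(=O)CCCCCCc2ccccc2)o1` gives 400 nM. The steps were a 1.2-fold higher number from compound 1 to compound 3 (0.07 log units; within the scatter) and a 3.1-fold lower number from compound 2 to compound 3 (0.49 log units; beyond the scatter). Compound 4 `Nc1cccc(-c2cnc(C(=O)CCCCCCc3ccccc3)o2)c1` carries 3-aminophenyl in place of 2-cyanophenyl on an aromatic carbon. Both measured steps that touch the nitrile were modest or within the scatter, and neither involved an amino group, so this change is only partly covered by the data. The expected step is a 1.9-fold higher number from compound 3 to compound 4 (0.28 log units; within the scatter), small and toward a slightly higher number, with wide uncertainty. Compound 4 is expected at 250 nM, with a range from 80 nM to 800 nM.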

Compound 4, inhibition constant: 19 nM
Beside the measured number, compound 4's estimate is 13-fold (1.12 log units) above it, outside the stated range (below it).
By their numbers in this assay, from the lowest: compound 4; then compounds 1 and 3 (each within the scatter of the next); then compound 2.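

For the compounds shown here, changing the aromatic group on this carbon can matter more than the earlier compounds showed: in this assay the switch to 3-aminophenyl gives a 6.8-fold lower number from compound 3 to compound 4 (0.84 log units; beyond the scatter) and a 5.8-fold lower number from compound 1 to compound 4 (0.76 log units; beyond the scatter) and a 21-fold lower number from compound 2 to compound 4 (1.32 log units; beyond the scatter) and so places compound 4 below all three. Unlike 2-cyanophenyl, 3-aminophenyl counts a hydrogen-bond donor, but nothing at hand explains the lower number. The change replaces the substituent and moves it on the phenyl ring at once, so the two effects cannot be separated. Comparing 2-aminophenyl and 3-cyanophenyl would pull them apart.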